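Dropping the chloro from the aryl group of the core

The compounds below may be only part of what the source reports. "The series", "measured", "known", "first", "only" and "open" are said of these compounds alone.

Compound 1 `CCOC(=O)C1=CC(c2ccc(Cl)cc2)C2=C(CC(C)(C)CC2=O)N1` carries the only number shown for the series: in an assay on isolated protein for inhibition of glucose-6-phosphatase catalytic subunit 1 (Homo sapiens), read by inositol phosphate accumulation, with a stated time of 30 min, tested at 100 uM (on this read-out higher numbers stand for more inhibition at the one concentration tested (going by the name of the read-out) and lower numbers for less inhibition), compound 1 gives 11.3%. Compound 2 `CCOC(=O)C1(O)CC(c2ccc(Cl)cc2)C2=C(CC(C)(C)CC2=O)O1` is recorded in this assay only as "not active" (no number reported), without a number. Compound 3 `CCOC(=O)C1=CC(c2ccccc2)C2=C(CC(C)(C)CC2=O)N1` differs from compound 1 by hydrogen in place of chloro on an aromatic carbon. Within the data shown here, no step between measured compounds covers this change, so the expectation rests on compound 1 alone. In this assay the expected step is small, downward or none beyond the scatter: a number 3.3 percentage points lower from compound 1 to compound 3 (within the scatter). For compound 3 the estimate in this assay is 8%, within 0% to 20%.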

Compound 3, a percentage reported as inhibition, at one concentration (the size of the read-out at that concentration, not a potency): "not active" (no number reported)
The entry for compound 3 holds no number; the estimate stays without a comparison.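

Among these compounds, compound 3 is recorded as not active without a number, so no step from compound 1 to compound 3 can be read. The compounds shown leave open whether going from 4-chlorophenyl to phenyl shifts inhibition at all. Nothing further is at hand that bears on this result.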